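This account rests on a few compounds, and the source may have more. Where it says the series, first, only, none or still open, it means among the compounds named here.

Of the compounds shown here, three sharing one core have been tested in a functional assay for inhibition of sodium/hydrogen exchanger (Oryctolagus cuniculus); a higher number here means a weaker inhibitor, a lower number a stronger inhibitor. Compound 1 `Cc1cc(Cl)c(S(C)(=O)=O)cc1C(=O)N=C(N)N` gives 25 nM in this assay. Compound 2 `CCc1cc(Cl)c(S(C)(=O)=O)cc1C(=O)N=C(N)N` gives 63 nM, and compound 3 `CS(=O)(=O)c1cc(C(=O)N=C(N)N)ccc1Cl` gives 380 nM. Compound 2 therefore stands second highest of the three numbers: there is a 2.5-fold higher number from compound 1 to compound 2 (0.40 log units; beyond the scatter), there is a 6.0-fold higher number from compound 2 to compound 3 (0.78 log units; beyond the scatter), and between the outer pair there is a 15-fold higher number from compound 1 to compound 3 (1.18 log units; beyond the scatter).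

Compound 4 `CCc1cc(-n2ccc(=O)cc2)c(S(C)(=O)=O)cc1C(=O)N=C(N)N` has not yet been measured. It differs from compound 2 in one place: a group of 7 heavy atoms (5 carbon, 1 nitrogen, 1 oxygen; one six-membered aromatic ring with 1 hetero atom) in place of one chlorine atom, on an aromatic carbon. None of the three measured steps touches this place; each of them concerns only the methyl or ethyl group, so they offer no direct guidance on swapping the chlorine for the new group. The expectation for compound 4 is therefore held loosely, leaning toward a modest weakening, and the expected step is a 1.9-fold higher number from compound 2 to compound 4 (0.28 log units; within the scatter). Compound 4 is estimated at 120 nM, with a range from 25 nM to 600 nM.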

Compound 4, half-maximal inhibitory concentration: 930 nM
The estimate for compound 4 lay 7.8-fold (0.89 log units) below the measured number, outside the stated range (above it).
By their numbers in this assay, from the lowest: compound 1; then compound 2; then compound 3; then compound 4.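

In this assay the aromatic carbon ortho to a methylsulfonyl group proves sensitive to what it carries: the new ring group in place of chloro gives a 15-fold higher number from compound 2 to compound 4 (1.17 log units; beyond the scatter) and so makes a much weaker inhibitor. The change is not a complete loss of activity, since compound 4 still gives a measurable 930 nM in this assay. This single swap alters the size, the ring and the hydrogen-bond acceptor count all at once, and nothing available here explains the weakening.

The compounds shown leave open how a small amine or a methoxy group at this position would compare with chloro, and whether a plain phenyl ring would behave like the new group. They also leave open whether the same swap would give a step of similar size with methyl in place of ethyl, as in compound 1.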